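This account rests on a few compounds, and the source may have more. Where it says the series, first, only, none or still open, it means among the compounds named here.

Series notes.

Compound 1, `Cc1ccc(S(=O)(=O)Nc2ccc(-c3nc4ccccc4o3)cc2)cc1`: in an assay on isolated protein for inhibition of malate dehydrogenase, mitochondrial (Sus scrofa), with stated times of 45 min and 30 min (a lower number here means a stronger inhibitor, a higher number a weaker inhibitor), compound 1 gives > 63000 nM, which is a limit of the assay.
Compound 2, `COc1ccc(Cl)cc1S(=O)(=O)Nc1ccc(-c2nc3ccccc3o2)cc1`: in this assay compound 2 gives > 63000 nM, likewise a limit of the assay.

Where compound 2 stands: its value in this assay is a limit only, and the one further value shown for the series is a limit as well, so both measured compounds sit together at the limit of > 63000 nM in this assay, at which 2 of the 2 values shown sit. For the measured compounds named here, the single measured step, a step that the two limits leave unreadable from compound 1 to compound 2, cannot be read from these two limits.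

The next compound, compound 3, `O=S(=O)(Nc1ccc(-c2nc3ccccc3o2)cc1)c1ccc(Cl)c(Cl)c1`, differs from compound 2 by 3,4-dichlorophenyl in place of 5-chloro-2-methoxyphenyl on a sulfonyl sulfur. Going by the values given here, the only measured step concerns a change at the same position, but it gives no readable size, so neither a direction nor a magnitude can be taken from it. With both measured compounds reported only as limits, compound 3 is expected to give a limit again in this assay, and the step that the limit leaves unreadable from compound 2 to compound 3 is expected to stay within the scatter. Compound 3 is therefore estimated at 90000 nM, in the range 30000 nM to 300000 nM.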

Compound 3, half-maximal inhibitory concentration: > 63000 nM
Compound 3: no number, only a limit; the forecaster's own chance of this, stated with the estimate: 85%; the middle value lies beyond the limit too.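

In this assay compound 3 gives > 63000 nM, a limit of the assay. For the compounds shown here, no step among compound 1, compound 2 and compound 3 can be read, as all three stand at the same limit: the limit of > 63000 nM in this assay, at which 3 of the 3 values shown sit.

The compounds shown leave open whether any group on the sulfonyl sulfur of the shared core gives a measurable value in this assay.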